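The compounds below may be only part of what the source reports. "The series", "measured", "known", "first", "only" and "open" are said of these compounds alone.

Working notes on the series.

Compound 2 `CCCCCCc1nc(O)cc(O)n1` gives 454 nM in a functional assay on HEK293 cells for agonist activity at G-protein coupled receptor 84 (Homo sapiens), read by calcium flux (on this read-out higher numbers stand for an effect only at larger amounts of compound and lower numbers for an effect already at smaller amounts), the second highest of the three numbers in hand. Its nearest neighbour is compound 1 `CCCCCc1nc(O)cc(O)n1` with 3670 nM; the furthest is compound 3 `CCCCCCCc1cc(O)cc(O)n1`, a compound built on a different core, with 1.26 nM.

Compound 4 `CCCCCCCc1nc(O)cc(O)n1` is not yet measured. It differs from compound 2 by methyl in place of hydrogen on a saturated chain carbon, six bonds along the chain from an aromatic carbon.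

Within the data shown here, the one measured step that bears on this change is the same kind of extension one bond nearer the core: an 8.1-fold lower number from compound 1 to compound 2 (0.91 log units; beyond the scatter). Among the measured compounds shown here, compound 3 carries a seven-carbon chain like compound 4, but on another core, so no step to it is counted here; its value only shows that a chain of this length is compatible with a low number in this assay.

On that basis a further drop of roughly the same order is expected for compound 4, with a gap expected of a 5.7-fold lower number from compound 2 to compound 4 (0.75 log units; beyond the scatter), though a smaller gain than seen from compound 1 to compound 2 is possible. Compound 4 is estimated at 80 nM, within a range from 20 nM to 320 nM.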

Compound 4, half-maximal effective concentration: 12.7 nM
Estimate against measurement, compound 4: 6.3-fold (0.80 log units) above; measured number outside the range, below it.
By their numbers in this assay, from the lowest: compound 3; then compound 4; then compound 2; then compound 1.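

In this assay the methyl in place of hydrogen on a saturated chain carbon, six bonds along the chain from an aromatic carbon, gives a 36-fold lower number from compound 2 to compound 4 (1.55 log units; beyond the scatter) and so outdoes an 8.1-fold lower number from compound 1 to compound 2 (0.91 log units; beyond the scatter) on the shared core, where the gain from extending the chain has not levelled off at this length. The two extensions together amount to a 290-fold lower number from compound 1 to compound 4 (2.46 log units; beyond the scatter) and, across these three compounds on the shared core, each added carbon lowers the number, with none going against this. Nothing at hand gives a measured reason for the size of this step.

On these data alone, whether a longer chain on the shared core would lower the number further or reverse the trend remains open. Also open, as far as these compounds go, is what an amine or a carboxylic acid at the end of the chain would do to the number.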